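A few compounds are considered here, and "the series" means these few. Any claim that something is new, unique, unknown or untested is made for them only; others in the source may bear on it.

- Compound 1 `COc1cc(OC)c(/C=C/S(=O)(=O)Nc2ccc(OC)c(N)c2)c(OC)c1`: 3 nM
- Compound 2 `COC(=O)C(C)Nc1cc(NS(=O)(=O)/C=C/c2c(OC)cc(OC)cc2OC)ccc1OC`: 300 nM

In a functional assay on K562 cells (Homo sapiens) for cytotoxicity, read by trypan blue exclusion, with a stated time of 96 h (on this read-out higher numbers stand for weaker inhibition and lower numbers for stronger inhibition), compound 2 has the higher of the two numbers, 300 nM, making it the weaker inhibitor of the pair. Compound 3 `COC(=O)C(C)(C)Nc1cc(NS(=O)(=O)/C=C/c2c(OC)cc(OC)cc2OC)ccc1OC` differs from it in one place: methyl in place of hydrogen on a saturated chain carbon bound to a carbonyl carbon, a nitrogen on an aromatic ring and a saturated chain carbon. This is methyl in place of hydrogen on a saturated chain carbon bound to a carbonyl carbon, a nitrogen on an aromatic ring and a saturated chain carbon. Within the data shown here, the only measured step, a 100-fold higher number from compound 1 to compound 2 (2.00 log units; beyond the scatter), was large, but it added the whole 1-(methoxycarbonyl)ethyl group. Adding only a methyl to that group should therefore produce just a small upward step in this assay. The estimated value for compound 3 is 500 nM, with an expected range of 120 nM to 2500 nM. The expected step is a 1.7-fold higher number from compound 2 to compound 3 (0.22 log units; within the scatter).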

Compound 3, half-maximal inhibitory concentration: 300 nM
Beside the measured number, compound 3's estimate is 1.7-fold (0.22 log units) above it; the measured number falls inside the stated range.
By their numbers in this assay, from the lowest: compound 1; then compounds 2 and 3 (each within the scatter of the next).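

In this assay, adding a methyl at this saturated chain carbon gives no change at the digits printed from compound 2 to compound 3 (within the scatter), so here the change from 1-(methoxycarbonyl)ethyl to 1-(methoxycarbonyl)-1-methylethyl shifts the number by no more than the scatter. The larger group also stays far from the unsubstituted amine of compound 1, with a 100-fold higher number from compound 1 to compound 3 (2.00 log units; beyond the scatter), matching the earlier gap. Nothing here gives a reason for either step. Still open, going by these compounds, is whether a longer chain at this carbon, or a carboxylic acid in place of the methyl ester, would stay as close to compound 2.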